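The source may report more compounds than this note shows. Statements on the series, on what has been measured and on what is new or still open speak of the compounds shown alone.

Compound 1 `CCCC(C)Nc1nc(C)nc2c1nnn2-c1c(C)cc(C)cc1C`: 7.1 nM
Compound 2 `CCCC(CCC)Nc1nc(C)nc2c1nnn2-c1c(C)cc(C)cc1C`: 4 nM
Compound 3 `CCN(CC)c1nc(C)nc2c1ncn2-c1ccc(C(C)C)cc1Br`: 12.4 nM

All three were tested in an in vitro assay on 293-EBNA cells for binding affinity to corticotropin-releasing factor receptor 1 (Homo sapiens); a higher number here means a weaker inhibitor, a lower number a stronger inhibitor. Compound 1 and compound 2 share one core and differ in a single place: ethyl in place of hydrogen on a saturated chain carbon, two bonds along the chain from a nitrogen on an aromatic ring. That change gave a 1.8-fold lower number from compound 1 to compound 2 (0.25 log units; within the scatter). Compound 3 rests on another core; the difference between the two cores is not broken down here. In this assay compound 3 gives 12.4 nM, a number within the scatter of compound 1 and further from compound 2.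

Compound 4 `CCCCN(CC)c1nc(C)nc2c1ncn2-c1ccc(C(C)C)cc1Br` has not yet been measured. It differs from compound 3 by the same change, now made on the core of compound 3: ethyl in place of hydrogen on a saturated chain carbon, two bonds along the chain from a nitrogen on an aromatic ring. Because the earlier step of a 1.8-fold lower number from compound 1 to compound 2 (0.25 log units; within the scatter) stayed within the scatter, a comparably small step is expected from compound 3 to compound 4, namely a 1.4-fold lower number from compound 3 to compound 4 (0.14 log units; within the scatter). Compound 4 is therefore estimated at 9 nM, expected to fall between 4 nM and 20 nM.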

Compound 4, inhibition constant: 4.3 nM
Beside the measured number, compound 4's estimate is 2.1-fold (0.32 log units) above it; low and high end bracket the measured number.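

In this assay, ethyl in place of hydrogen on the core of compound 3 gave a 2.9-fold lower number from compound 3 to compound 4 (0.46 log units; beyond the scatter). Set beside the earlier step, the change carried over to the second core in the same direction, and the two steps do not differ beyond the scatter: the same change on two cores in this assay, a 1.8-fold lower number (0.25 log units; within the scatter) from compound 1 to compound 2 and a 2.9-fold lower number (0.46 log units; beyond the scatter) from compound 3 to compound 4, 1.6-fold (0.21 log units) apart, within the scatter of two such steps. This rests on one pair per core, so it shows agreement on these two cores only and does not show that the change would behave alike on any other core.

The compounds shown leave open what a pentyl chain, a cyclopropylmethyl group or a chain ending in a methoxy group would do at this place on either core.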